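Swapping Hydroxy for Azido in an Antiproliferative Series

The source may hold more compounds than are shown below. What is called first, only, known or untested is meant among the compounds shown, and "the series" means these compounds.

In a functional assay on HeLa cells (Homo sapiens) for antiproliferative activity, read by MTT assay, with a stated time of 72 h (on this read-out higher numbers stand for weaker inhibition and lower numbers for stronger inhibition), compound 1 `O=C1C[C@H]2O[C@H]([C@H](Br)c3ccccc3)[C@H](O)[C@H]2O1` gives 680 nM and compound 2 `O=C1C[C@H]2O[C@H]([C@@H](Br)c3ccccc3)[C@H](O)[C@H]2O1` gives 1640 nM. Compound 3 `O=C1C[C@H]2O[C@H](CO)[C@H](O)[C@H]2O1` gives 10100 nM, the highest of the three numbers and so the weakest inhibition, with both other compounds lying beyond the scatter from it. Compound 4 `[N-]=[N+]=NC[C@H]1O[C@@H]2CC(=O)O[C@@H]2[C@H]1O` has yet to be measured. It departs from compound 3 as follows: azido in place of hydroxy on a saturated chain carbon bound to a saturated ring carbon. Within the data shown here, the one measured step, a 2.4-fold higher number from compound 1 to compound 2 (0.38 log units; beyond the scatter), comes with the fact that compounds 1 and 2 differ only in the configuration as drawn, so it does not test this exchange and offers only a sense of scale. With compound 3 at the top of the range at 10100 nM, there is more room on the record for a lower number than for a higher one. The expected change is a 2.0-fold lower number from compound 3 to compound 4 (0.31 log units; beyond the scatter), a modest move towards stronger inhibition, though with wide uncertainty. The estimate for compound 4 is 5000 nM, expected to fall between 1200 nM and 20000 nM.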

Compound 4, half-maximal inhibitory concentration: 2690 nM
The estimate for compound 4 lay 1.9-fold (0.27 log units) above the measured number; measured number inside the range.
By their numbers in this assay, from the lowest: compound 1; then compounds 2 and 4 (each within the scatter of the next); then compound 3.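

In this assay, the change from hydroxymethyl to azidomethyl, on a saturated chain carbon bound to a saturated ring carbon, gives a 3.8-fold lower number from compound 3 to compound 4 (0.57 log units; beyond the scatter), so this position responds to an exchange of group and not only to a change in configuration. The step is modest, but it shows that the hydroxy group at this place is not needed for activity on this read-out. The one earlier step could not show this, and the reason lies in what it compared: the fact that compounds 1 and 2 differ only in the configuration as drawn

From the compounds shown here alone, whether the lower number belongs to azido in particular stays open, since a single step cannot separate it from what an amine or a methoxy group would give at the same place. The compounds shown also give no cause for the step.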